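The source may hold more compounds than are shown below. What is called first, only, known or untested is meant among the compounds shown, and "the series" means these compounds.

Measured so far:
Compound 1 `C=C/C=C\[C@H](C)[C@H](OC(N)=O)[C@@H](C)[C@H](O)CC/C=C\C(C)[C@@H](O)[C@@H](C)/C=C\CC[C@@H]1O[C@@H](OC)[C@H](C)[C@@H](OCOC)[C@@H]1C` gives 3.4 nM
Compound 2 `COCO[C@H]1[C@@H](C)[C@H](CC/C=C\[C@H](C)[C@H](O)[C@@H](C)/C=C\CC[C@@H](O)[C@H](C)COC(N)=O)OC(=O)[C@@H]1C` gives 30 nM

In a functional assay on cells (Homo sapiens) for inhibition (a higher number here means a weaker inhibitor of growth, a lower number a stronger inhibitor of growth), compound 1 gives 3.4 nM and holds the lower number of the two, which makes it the stronger inhibitor of growth. Compound 2 at 30 nM sits above it by more than the usual scatter.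

Compound 3 `CCCCCC[C@H](OC(N)=O)[C@@H](C)[C@H](O)CC/C=C\C(C)[C@@H](O)[C@@H](C)/C=C\CC[C@@H]1O[C@@H](OC)[C@H](C)[C@@H](OCOC)[C@@H]1C` keeps the core of compound 1 and changes one group: hexyl in place of 1-methylpenta-2,4-dien-1-yl on a saturated chain carbon bound to an oxygen next to a carbonyl group and a saturated chain carbon. Among the measured compounds shown here, no measured pair shows this kind of change, so the expectation rests on the structural change alone, and it is uncertain. A moderate rise in the number in this assay is expected, meaning a weaker inhibitor, probably beyond the scatter. The expected step of a 7.4-fold higher number from compound 1 to compound 3 (0.87 log units; beyond the scatter) carries that estimate. For compound 3 the estimated value is 25 nM with an expected range from 6 nM to 100 nM in this assay.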

Compound 3, concentration for 50% growth inhibition: 24 nM
Compound 3: the middle estimate sits 1.0-fold (0.02 log units) above what was measured, within the range that was stated.
By their numbers in this assay, from the lowest: compound 1; then compounds 3 and 2 (each within the scatter of the next).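

In this assay, putting hexyl in place of 1-methylpenta-2,4-dien-1-yl on a saturated chain carbon bound to an oxygen next to a carbonyl group and a saturated chain carbon gives a 7.1-fold higher number from compound 1 to compound 3 (0.85 log units; beyond the scatter), a weaker inhibitor of growth. Both groups hold 6 heavy atoms, all carbon, so the number at this position can move beyond the scatter with no change in that count; what leaves with the change is 2 double bonds and 1 defined stereocentre. No measurement at hand explains the step.

The compounds shown leave open whether the double bonds, the stereocentre or both account for the difference. On these data alone, how a shorter butyl chain, a longer octyl chain or a phenyl ring would read at this position also remains open.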